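The source may report more compounds than this note shows. Statements on the series, on what has been measured and on what is new or still open speak of the compounds shown alone.

Compound 1 `c1ccc(-c2ccoc2)c(OCC2=NCCN2)c1`: 104%
Compound 2 `Cc1ccoc1-c1ccccc1OCC1=NCCN1`: 99%
Compound 3 `Cc1csc(-c2ccccc2OCC2=NCCN2)n1`: 104%

In a functional assay with Alpha-1A adrenergic receptor (Homo sapiens) as the target, read by calcium flux (on this read-out higher numbers stand for larger maximal responses and lower numbers for smaller maximal responses), compound 3 gives 104%. The measured steps place it level with compound 1, no change at the digits printed from compound 1 to compound 3 (within the scatter), while a number 5 percentage points higher from compound 2 to compound 3 (within the scatter); neither step is beyond the scatter. Compound 4 `Cn1nccc1-c1ccccc1OCC1=NCCN1` differs from compound 3 by one change: 1-methyl-1H-pyrazol-5-yl in place of 4-methyl-1,3-thiazol-2-yl on an aromatic carbon. All three measured steps concern the same kind of exchange, one five-membered aromatic ring for another at the same position on the shared core, and each stayed within the scatter, with a number 5 percentage points lower from compound 1 to compound 2 (within the scatter) being the largest. On that basis the step from compound 3 to compound 4 is expected to be a number 2 percentage points lower from compound 3 to compound 4 (within the scatter), that is, nothing beyond the scatter. Compound 4 is therefore estimated at 102% in this assay, with a range from 90% to 112%.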

Compound 4, largest response reached (reported as maximum), in percent of the reference or control that the assay uses: 107%
Estimate against measurement, compound 4: 5 percentage points below; the range from low to high includes it.
By their numbers in this assay, from the lowest: compounds 2, 1, 3 and 4 (each within the scatter of the next).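

In this assay the 1-methyl-1H-pyrazol-5-yl group, with 2 nitrogen atoms in its ring, gives the same picture as the other five-membered aromatic rings on this aromatic carbon (a number 3 percentage points higher from compound 3 to compound 4 (within the scatter); a number 3 percentage points higher from compound 1 to compound 4 (within the scatter)). The widest gap so far at this position also stays inside the usual variation (a number 8 percentage points higher from compound 2 to compound 4 (within the scatter)). All four rings therefore give maximal responses that cannot be told apart. As far as these compounds go, whether an amine or a carboxylic acid here would hold the response remains open. Nothing measured explains the result.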